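The source may report more compounds than this note shows. Statements on the series, on what has been measured and on what is new or still open speak of the compounds shown alone.

Compound 1 `COc1cc2c(/C=C3/C(=O)Nc4ccc(O)cc43)c(Cl)n(Cc3cc(OC)c(OC)c(OC)c3)c2cc1C` is one of two compounds with a measured number in a functional assay on cells (Cancer cell lines, Homo sapiens) for cytotoxicity, with a stated time of 48 h; on this read-out lower numbers stand for stronger inhibition of growth and higher numbers for weaker inhibition of growth. In this assay compound 1 gives 2290 nM. Among the measured compounds shown here, compound 2 `O=C1/C(=C/c2c(Cl)[nH]c3ccccc23)c2ccccc2N1Cc1ccccc1` is the only other measured compound, and in this assay compound 2 gives 6170 nM. Compound 1 therefore stands at the lowest of the two numbers, and the gap to compound 2 lies beyond the usual scatter of such measurements. For the measured compounds named here, the two share no single-point step, so their values can only be set side by side.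

Compound 3 `COc1cc2c(/C=C3/C(=O)Nc4cccc(Cl)c43)c(Cl)n(Cc3cc(OC)c(OC)c(OC)c3)c2cc1C` has not yet been measured. It differs from compound 1 by a group of 12 heavy atoms (9 carbon, 1 nitrogen, 1 oxygen, 1 chlorine; one five-membered non-aromatic ring with 1 hetero atom, one six-membered aromatic ring of carbon only) in place of a group of 12 heavy atoms (9 carbon, 1 nitrogen, 2 oxygen; one five-membered non-aromatic ring with 1 hetero atom, one six-membered aromatic ring of carbon only), on an aromatic carbon, on an aromatic carbon of a five-membered aromatic ring with 1 nitrogen that is part of a fused system of two rings, two ring bonds from the ring nitrogen. The group that leaves carries 2 hydrogen-bond donors and 2 hydrogen-bond acceptors; the group that enters carries 1 of each. Going by the values given here, no measured pair shows what this exchange does, so compound 3 is expected to stay close to compound 1, with a step of a 1.3-fold higher number from compound 1 to compound 3 (0.12 log units; within the scatter) that may not exceed the scatter. Compound 3 is estimated at 3000 nM, within 1000 nM to 9000 nM.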

Compound 3, concentration for 50% growth inhibition: 1910 nM
The estimate for compound 3 lay 1.6-fold (0.20 log units) above the measured number; the measured number falls inside the stated range.
By their numbers in this assay, from the lowest: compounds 3 and 1 (each within the scatter of the next); then compound 2.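

Among the compounds shown here, the exchange at this place, on an aromatic carbon of a five-membered aromatic ring with 1 nitrogen, gives the first single-place step in this assay, where the earlier compounds could only be set side by side: the step is a 1.2-fold lower number from compound 1 to compound 3 (0.08 log units; within the scatter), which lies within the scatter. The group that enters has a chlorine in place of one of the oxygens of the group that leaves, and carries 1 hydrogen-bond donor and 1 hydrogen-bond acceptor against 2 of each, yet this read-out does not separate the two compounds. This place therefore accepts this one change with no measurable difference in growth inhibition, and no measurement shown bears on why the number holds.

As far as these compounds go, what stays open is whether a group bearing an amine or a carboxylic acid in place of that chlorine would also leave the number within the scatter of compound 1, or would move it clearly in either direction. A single step also leaves open whether the same exchange would read alike on a core other than that of compound 1.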